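Propyl removal on the cinnamide ring of compound 1

The compounds below may be only part of what the source reports. "The series", "measured", "known", "first", "only" and "open" are said of these compounds alone.

Measured compounds:
compound 1 `CCCc1ccc(/C=C/C(=O)Nc2ccc3nc(CCC)cc(N)c3c2)cc1`, 4 nM
compound 2 `Nc1cc(-c2ccccc2)nc2ccc(NC(=O)/C=C/c3ccc(C(F)(F)F)cc3)cc12`, 18.5 nM

Among the measured compounds shown here, in an assay on isolated protein for displacement of a labelled ligand from melanin-concentrating hormone receptor 1 (Homo sapiens) (on this read-out higher numbers stand for weaker inhibition and lower numbers for stronger inhibition), compound 1 gives the lowest of the two numbers measured so far; compound 2 gives a number higher by more than the usual scatter. For the measured compounds named here, compound 2 differs from compound 1 in more than one place, so no single step between the two is counted.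

Compound 3 `CCCc1cc(N)c2cc(NC(=O)/C=C/c3ccccc3)ccc2n1` has not yet been measured. It differs from compound 1 by hydrogen in place of propyl on an aromatic carbon, the same difference, cut one bond further out, reading 4-propylphenyl to phenyl. Going by the values given here, no measured pair isolates this change. Compound 1, with the propyl in place, gives 4 nM, and compound 3 is expected to give a somewhat higher number, a step of a 3.8-fold higher number from compound 1 to compound 3 (0.57 log units; beyond the scatter), likely beyond the scatter but moderate. Compound 3 is estimated at 15 nM, range 5 nM to 50 nM.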

Compound 3, half-maximal inhibitory concentration: 1000 nM
Compound 3: the middle estimate sits 67-fold (1.82 log units) below what was measured; the whole stated range lies below it.
By their numbers in this assay, from the lowest: compound 1; then compound 2; then compound 3.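

In this assay, among the compounds shown here, hydrogen in place of propyl, on an aromatic carbon para to a large group, gives a 250-fold higher number from compound 1 to compound 3 (2.40 log units; beyond the scatter) and is the first change that can be read at a single position. The core of compound 1 and its propyl on the other ring system stay the same across this step, so the low number of compound 1 depends on the propyl at this position and not on the shared core alone. Nothing measured here bears on why the step is so large.

Still open, as far as these compounds go, is whether the number follows this particular chain or any group at this carbon, which methyl, ethyl or butyl there would separate. A methoxy group or an amine at the same carbon would show whether a chain of carbon atoms is needed at all.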